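Cytotoxicity series on the shared core: compound 3 to compound 4

A few compounds are considered here, and "the series" means these few. Any claim that something is new, unique, unknown or untested is made for them only; others in the source may bear on it.

Measured compounds:
- compound 1 `C=CCn1c(=O)/c(=C\c2cccc(F)c2)[nH]c(=O)/c1=C\c1ccccc1OC`: 27200 nM
- compound 2 `C=CCn1c(=O)/c(=C\c2cc(Br)ccc2F)[nH]c(=O)/c1=C\c1ccccc1OC`: "not active" (no number reported) (no number reported)
- compound 3 `C=CCn1c(=O)/c(=C\c2ccccc2C(F)(F)F)[nH]c(=O)/c1=C\c1ccccc1OC`: 9500 nM

In a functional assay on Huh-7 cells (Homo sapiens) for cytotoxicity, read by CCK-8 assay, with a stated time of 72 h (on this read-out higher numbers stand for weaker inhibition and lower numbers for stronger inhibition), compound 3 gives 9500 nM, the lowest of the two numbers available. Its nearest neighbour is compound 1, which differs only in the aryl group on the double-bonded chain carbon and gives 27200 nM; the step of a 2.9-fold lower number from compound 1 to compound 3 (0.46 log units; beyond the scatter) is beyond the scatter. Compound 2, a bromo-fluorophenyl analogue at the same position, gives "not active" (no number reported), so no number stands for it.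

Compound 4 `C=CCn1c(=O)/c(=C\c2ccc(F)c(Br)c2)[nH]c(=O)/c1=C\c1ccccc1OC` is unmeasured. It differs from compound 3 by 3-bromo-4-fluorophenyl in place of 2-(trifluoromethyl)phenyl on a double-bonded chain carbon bound to an aromatic carbon. Within the data shown here, only the step from compound 1 to compound 3 bears directly on this position, and it was modest. Among the measured compounds shown here, the closest precedent for a bromo-fluorophenyl group here is compound 2, which returned no number in this assay. A weaker result than compound 3 is therefore expected, with a 3.2-fold higher number from compound 3 to compound 4 (0.50 log units; beyond the scatter) as the expected step. For compound 4 the estimate in this assay is 30000 nM, within 9000 nM to 100000 nM.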

Compound 4, half-maximal inhibitory concentration: "not active" (no number reported)
Compound 4 has no reported number here, so the estimate cannot be set against anything.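

Compound 4, like compound 2, is reported as "not active" without a number in this assay, so no new step can be read from compound 3 or any other compound. No supporting evidence bears on this result. The compounds shown leave open how a bromo-fluorophenyl group compares numerically with 2-(trifluoromethyl)phenyl.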